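This account rests on a few compounds, and the source may have more. Where it says the series, first, only, none or still open, it means among the compounds named here.

Working notes on the series. In a functional assay on FM3A cells (Mus musculus) for inhibition (on this read-out higher numbers stand for weaker inhibition and lower numbers for stronger inhibition), compound 1 `O=c1[nH]c(=O)n([C@H]2C[C@H](O)[C@@H](CO)O2)cc1C#CI` gives 87000 nM. For compound 2 `C[Si](C)(C)C#Cc1cn([C@H]2C[C@H](O)[C@@H](CO)O2)c(=O)[nH]c1=O` this assay reports only a limit, >= 250000 nM. Within the data shown here, the single measured step, an at least 2.8-fold higher number from compound 1 to compound 2 (0.45 log units; beyond the scatter), thus already runs up to the limit; see (the limit of >= 250000 nM in this assay, at which 2 of the 3 values shown sit). Compound 3 `C#Cc1cn([C@@H]2O[C@H](CO)[C@@H](O)[C@@H]2O)c(=O)[nH]c1=O` is the starting point of the present step, and in this assay it too reaches only a limit, >= 250000 nM, so it stands at the weakest reading the assay can report, with no number beneath it. Compound 4 `C[Si](C)(C)C#Cc1cn([C@@H]2O[C@H](CO)[C@@H](O)[C@@H]2O)c(=O)[nH]c1=O` differs from compound 3 by a group of 4 heavy atoms (3 carbon, 1 silicon; no ring) in place of a hydrogen atom, on a triple-bonded carbon. Among the measured compounds shown here, the one measured step that bears on this change is an at least 2.8-fold higher number from compound 1 to compound 2 (0.45 log units; beyond the scatter), in which the same group of 4 heavy atoms (3 carbon, 1 silicon; no ring) entered on a triple-bonded carbon and the reading moved to the limit. The same direction, weaker inhibition, or no measurable change from a value already at the limit, is therefore expected here. The step that the limit leaves unreadable from compound 3 to compound 4 is the expected outcome. Compound 4 is estimated at 300000 nM, with a range of 200000 nM to 600000 nM, and is expected most probably to be reported again only as a limit.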

Compound 4, half-maximal inhibitory concentration: >= 250000 nM
Compound 4: no number, only a limit; the forecaster's own chance of this, stated with the estimate: 85%; the middle value lies beyond the limit too.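

Compound 4 reads >= 250000 nM in this assay and this is a limit, not a number. No step from compound 3 or compound 2 to compound 4 can be read, since all three stand only at a limit: the limit of >= 250000 nM in this assay, at which 3 of the 4 values shown sit.

The compounds shown leave open whether the group of 4 heavy atoms changes inhibition when it replaces a hydrogen atom on the triple-bonded carbon of compound 3.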